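From chloro to cyclohexyl on a saturated chain

This account rests on a few compounds, and the source may have more. Where it says the series, first, only, none or still open, it means among the compounds named here.

Measured in a functional assay on NCI-H460 cells (Homo sapiens) for cytotoxicity, read by MTT assay, with a stated time of 48 h; a higher number here means a weaker inhibitor, a lower number a stronger inhibitor:
- compound 1 `C=C1C(=O)O[C@H]2CC3=C[C@H](C/C(C)=C/[C@@H](OC(=O)/C=C/c4ccccc4)[C@H]12)OC3=O`: > 10000 nM, a limit
- compound 2 `C=C1C(=O)O[C@H]2CC3=C[C@H](C/C(C)=C/[C@@H](OC(=O)CCCCC)[C@H]12)OC3=O`: 5900 nM
- compound 3 `C=C1C(=O)O[C@H]2CC3=C[C@H](C/C(C)=C/[C@@H](OC(=O)CCl)[C@H]12)OC3=O`: > 10000 nM, a limit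

Compound 3 is known only by a limit, > 10000 nM. It sits at the limit of > 10000 nM in this assay, at which 2 of the 3 values shown sit. Compound 4 `C=C1C(=O)O[C@H]2CC3=C[C@H](C/C(C)=C/[C@@H](OC(=O)CC4CCCCC4)[C@H]12)OC3=O` carries cyclohexyl in place of chloro on a saturated chain carbon bound to a carbonyl carbon. Within the data shown here, two measured steps bear on this change: an at least 1.6-fold higher number from compound 2 to compound 3 (0.22 log units; that floor lies within the scatter), where chloro replaces butyl at the same place, and an at least 1.6-fold lower number from compound 1 to compound 2 (0.22 log units; that floor lies within the scatter). Neither floor is large, so only a modest shift toward a lower number in this assay is expected. Compound 4 is expected to fall near compound 2 at 5900 nM. The expected step is an at least 1.5-fold lower number from compound 3 to compound 4 (0.18 log units; that floor lies within the scatter). For compound 4 the estimated value is 6500 nM, with an expected range of 3000 nM to 12000 nM.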

Compound 4, half-maximal inhibitory concentration: 2000 nM
Estimate against measurement, compound 4: 3.3-fold (0.51 log units) above; measured number below the stated range.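

In this assay, among these compounds, cyclohexyl in place of butyl gives a 3.0-fold lower number from compound 2 to compound 4 (0.47 log units; beyond the scatter) and so shows, as no earlier step could, that this place on a saturated chain carbon bound to a carbonyl carbon separates two groups of carbon only. Cyclohexyl in place of chloro gives an at least 5.0-fold lower number from compound 3 to compound 4 (0.69 log units; beyond the scatter) and cyclohexylmethyl in place of 2-phenylethenyl gives an at least 5.0-fold lower number from compound 1 to compound 4 (0.69 log units; beyond the scatter) as floors only. Compound 1 and compound 3 are each known only by a limit: the limit of > 10000 nM in this assay, at which 2 of the 4 values shown sit.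

From the compounds shown here alone, whether a longer chain, an amine or a carboxylic acid at this place would keep the number as low stays open.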